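This account rests on a few compounds, and the source may have more. Where it says the series, first, only, none or still open, it means among the compounds named here.

Among the compounds with values here, all three compounds measured so far in a functional assay on HeLa cells (Homo sapiens) for inhibition (a lower number here means a stronger inhibitor, a higher number a weaker inhibitor), carry a 2-formylethenyl group. Compound 1 `Cc1cn(COCCO)c(=O)n(/C=C/C=O)c1=O` gives 20000 nM, compound 2 `O=C/C=C/n1c(=O)c(I)cn([C@H]2C[C@H](O)[C@@H](CO)O2)c1=O` gives 80000 nM, and compound 3 `O=C/C=C/n1c(=O)ccn([C@H]2C[C@H](O)[C@@H](CO)O2)c1=O` gives 15000 nM. Compound 3 has the lowest of these three numbers, but its gap to compound 1 lies within the scatter, so those two cannot be ranked. Only against compound 2 does it clearly stand apart.

The next compound, compound 4 `N#C/C=C/n1c(=O)ccn([C@H]2C[C@H](O)[C@@H](CO)O2)c1=O`, has cyano in place of formyl on a double-bonded chain carbon bound to a double-bonded chain carbon. Within the data shown here, the one measured single change is a 5.3-fold lower number from compound 2 to compound 3 (0.73 log units; beyond the scatter), with hydrogen in place of iodo on an aromatic carbon. That step is modest, but it concerns a different group, so it bears only loosely on this swap. Among the measured compounds shown here, no measured compound lacks the formyl group, which leaves the data without a direct guide, and even the direction is a judgement. A modest loss of inhibition seems the more cautious expectation, so the expected step is a 2.3-fold higher number from compound 3 to compound 4 (0.37 log units; beyond the scatter). For compound 4 the estimated value is 35000 nM, with an expected range from 10000 nM to 120000 nM.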

Compound 4, half-maximal inhibitory concentration: 100000 nM
The estimate for compound 4 lay 2.9-fold (0.46 log units) below the measured number, and the stated range covers the measured number.
By their numbers in this assay, from the lowest: compounds 3 and 1 (each within the scatter of the next); then compounds 2 and 4 (each within the scatter of the next).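

Within the data shown here, the swap of 2-formylethenyl to 2-cyanoethenyl is the first change seen at this place, on a double-bonded chain carbon bound to a double-bonded chain carbon, and in this assay it gives a 6.7-fold higher number from compound 3 to compound 4 (0.82 log units; beyond the scatter) as a step beyond the scatter. Inhibition in this series therefore depends on what this group is, and not only on the group changed between compound 2 and compound 3. The two groups match in heavy atoms and hydrogen-bond acceptors under the computed comparison, so these counts alone do not account for the shift, and no measurement at hand says why the number rises with this swap.

On these data alone, whether formyl is specifically favoured at this place, or cyano is specifically poor, stays open, and a carboxylic acid, a methyl ester or a primary amide in the same place would help to separate those two readings. As far as these compounds go, the swap has also been read on the core of compound 3 alone, so whether the same step would appear on the core of compound 1 or with the iodo group of compound 2 remains unknown.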